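A few compounds are considered here, and "the series" means these few. Any claim that something is new, unique, unknown or untested is made for them only; others in the source may bear on it.

Working notes on the series. Compound 1 `COc1ccc(-c2ssc(=S)c2-c2cc(OC)c(OC)c(OC)c2)cc1O` in a functional assay on SGC-7901 cells (Homo sapiens) for antiproliferative activity, read by MTT assay, with a stated time of 72 h (a lower number here means a stronger inhibitor, a higher number a weaker inhibitor), gives 271 nM. Compound 2 `COc1ccc(-c2ssc(=S)c2-c2cc(OC)c(OC)c(OC)c2)cc1[N+](=O)[O-]` differs from compound 1 by nitro in place of hydroxy on an aromatic carbon, and this single change produced a 50-fold higher number from compound 1 to compound 2 (1.70 log units; beyond the scatter); in this assay compound 2 gives 13600 nM. Compound 3 `COc1ccc(-c2ssc(=O)c2-c2cc(OC)c(OC)c(OC)c2)cc1O` keeps the hydroxy group but sits on a different core; the difference between the two cores is not broken down here. In this assay compound 3 gives 3110 nM, a weaker inhibitor than compound 1 and a stronger one than compound 2.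

Compound 4 `COc1ccc(-c2ssc(=O)c2-c2cc(OC)c(OC)c(OC)c2)cc1[N+](=O)[O-]` is not yet measured. Going by the values given here, it differs from compound 3 by nitro in place of hydroxy on an aromatic carbon, the same change at the same place as the one from compound 1 to compound 2. Among the compounds with values here, the step from compound 3 to compound 4 is expected to be large and in the same direction, because a 50-fold higher number from compound 1 to compound 2 (1.70 log units; beyond the scatter) is the only measured instance of this change and it lay far beyond the scatter. The expected step is a 29-fold higher number from compound 3 to compound 4 (1.46 log units; beyond the scatter), allowing a little attenuation from a weaker starting point. Compound 4 is therefore estimated at 90000 nM, with a range from 25000 nM to 300000 nM; a reading this high may fall outside the assay range and be returned only as a limit.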

Compound 4, half-maximal inhibitory concentration: 440 nM
Compound 4: middle estimate off by 200-fold (2.31 log units), on the high side; the measured number lies below the stated range.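

In this assay, nitro in place of hydroxy on an aromatic carbon gives a 7.1-fold lower number from compound 3 to compound 4 (0.85 log units; beyond the scatter), so on this core the change runs opposite to its direction on the core of compound 1. The change therefore does not carry from one core to the other in either size or direction: the same change on two cores in this assay, a 50-fold higher number (1.70 log units; beyond the scatter) from compound 1 to compound 2 and a 7.1-fold lower number (0.85 log units; beyond the scatter) from compound 3 to compound 4, 350-fold (2.55 log units) apart, beyond the scatter of two such steps

This shows that, for these two matched pairs, the outcome of the change depends on the core it sits on, but it does not show what in the cores produces the reversal, and two pairs give no rule for predicting the step on any further core.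

The compounds shown cover only hydroxy and nitro at this place, so it remains open whether the reversal is specific to nitro or would also appear with an amine or a carboxylic acid there. From the compounds shown here alone, it also remains open whether other groups at this place would separate the two cores at all.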